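Nitro to methylcarbamoyl on the benzylic aryl ring

The source may report more compounds than this note shows. Statements on the series, on what has been measured and on what is new or still open speak of the compounds shown alone.

Compound 1 `O=[N+]([O-])c1cccc(CNc2cc(C(F)(F)F)cc3[nH]ncc23)c1` gives 5170 nM in an assay for inhibition of Tryptophan 2,3-dioxygenase (Homo sapiens), with stated times of 10 min and 60 min (a higher number here means a weaker inhibitor, a lower number a stronger inhibitor), and holds the highest of the two numbers in this set. Compound 3 `CS(=O)(=O)c1ccc(CNc2cc(C(F)(F)F)cc3[nH]ncc23)c([N+](=O)O)c1` gives 790 nM in this assay, a clearly lower number. Compound 2 `O=[N+]([O-])c1ccc2[nH]c(CNc3cc(C(F)(F)F)cc4[nH]ncc34)cc2c1` sits at a limit of this assay, > 100000 nM, which is not a number; it is a case of the limit of > 100000 nM in this assay, at which 1 of the 3 values shown sits. Compound 4 `CNC(=O)c1cccc(CNc2cc(C(F)(F)F)cc3[nH]ncc23)c1` has not yet been measured in this assay. It differs from compound 1 by methylcarbamoyl in place of nitro on an aromatic carbon. Within the data shown here, no step between measured compounds covers this change, so the expectation rests on compound 1 alone. The step of a 2.3-fold higher number from compound 1 to compound 4 (0.37 log units; beyond the scatter) is expected to run toward a weaker inhibitor, of moderate size. Compound 4 is estimated at 12000 nM in this assay, within 3000 nM to 50000 nM.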

Compound 4, half-maximal inhibitory concentration: 4870 nM
The estimate for compound 4 lay 2.5-fold (0.39 log units) above the measured number; low and high end bracket the measured number.
By their numbers in this assay, from the lowest: compound 3; then compounds 4 and 1 (each within the scatter of the next). At a limit, above all of these: compound 2.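

At this aromatic carbon, meta to a large group, methylcarbamoyl in place of nitro reads in this assay as a 1.1-fold lower number from compound 1 to compound 4 (0.03 log units; within the scatter). Nitro is therefore not needed here to keep the number of compound 1, and this position tolerates an amide carrying a hydrogen-bond donor. No available evidence accounts for this match between the two groups.

On these data alone, whether an amine, a carboxylic acid or a longer chain on the amide nitrogen would hold the number at this carbon stays open. So does whether methylcarbamoyl can replace nitro on the ring of compound 3.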